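The source may report more compounds than this note shows. Statements on the series, on what has been measured and on what is new or still open speak of the compounds shown alone.

Series so far, in an ADME assay on the whole organism (Rattus norvegicus) for pharmacokinetics, at a dose of 10 mg/kg by the oral route; a lower number here means less compound in the circulation, a higher number more compound in the circulation at the dose given
compound 1 `C[C@@H](Oc1cc(C(=O)N(C)C)ccc1Nc1nc(O[C@H]2CC[C@@](C)(O)CC2)c2cc[nH]c2n1)C(F)(F)F` gives 15600 ng.h/mL
compound 2 `CCOc1cc(C(=O)N(C)C)ccc1Nc1nc(O[C@H]2CC[C@@](C)(O)CC2)c2cc[nH]c2n1` gives "not determined" (no result reported)
compound 3 `CN(C)C(=O)c1ccc(Nc2nc(O[C@H]3CC[C@@](C)(O)CC3)c3cc[nH]c3n2)c(OCC(F)(F)F)c1` gives 8170 ng.h/mL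

Going by the values given here, compound 3 and compound 1 hold the only two numbers, and these lie within the scatter of each other (a 1.9-fold lower number from compound 1 to compound 3 (0.28 log units; within the scatter)). Next is compound 4 `COc1cc(C(=O)N(C)C)ccc1Nc1nc(O[C@H]2CC[C@@](C)(O)CC2)c2cc[nH]c2n1`, with hydrogen in place of trifluoromethyl on a saturated chain carbon bound to an oxygen on an aromatic ring, that is, 2,2,2-trifluoroethoxy to methoxy. Among the compounds with values here, the one measured step at this carbon stayed within the scatter (a 1.9-fold lower number from compound 1 to compound 3 (0.28 log units; within the scatter)), though it removed only a methyl, and compound 2 offers no number. No step beyond the scatter is therefore expected, the estimated step being small (a 1.2-fold lower number from compound 3 to compound 4 (0.07 log units; within the scatter)). Estimated for compound 4: 7000 ng.h/mL (expected range 2500 ng.h/mL to 18000 ng.h/mL).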

Compound 4, area under the concentration-time curve: 9580 ng.h/mL
Compound 4: middle estimate off by 1.4-fold (0.14 log units), on the low side; low and high end bracket the measured number.
By their numbers in this assay, from the lowest: compounds 3, 4 and 1 (each within the scatter of the next).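

In this assay, the change from 2,2,2-trifluoroethoxy to methoxy (a 1.2-fold higher number from compound 3 to compound 4 (0.07 log units; within the scatter)) and the change from 1-(trifluoromethyl)ethyl to methyl (a 1.6-fold lower number from compound 1 to compound 4 (0.21 log units; within the scatter)) both stay within the scatter. Unlike the earlier step, which removed only a methyl, these two remove the trifluoromethyl itself, so at this dose the read-out does not depend on that group being present on the chain. No measurement at hand gives a reason for this result.

Still open, going by these compounds, is whether a longer chain or a chain bearing an amine on this oxygen would stay in the same range.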